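The source may report more compounds than this note shows. Statements on the series, on what has been measured and on what is new or still open speak of the compounds shown alone.

Measured compounds:
- compound 1, `COc1cc(/C=N\NC(=O)C2=C(Cl)c3ccccc3CCC2)cc(OC)c1OC`, < 10 nM
- compound 2, `Cc1cc2c(cc1C)C(Cl)=C(C(=O)N/N=C\c1ccc(Cl)cc1)CCC2`, 18300 nM
- compound 3, `O=C(N/N=C/C1=C(Cl)c2ccccc2CCC1)c1ccccc1`, 16100 nM

Three compounds have been run in a functional assay on IMR-32 cells (Homo sapiens) for inhibition, read by sulforhodamine B assay, with a stated time of 48 h; on this read-out higher numbers stand for weaker inhibition of growth and lower numbers for stronger inhibition of growth. For compound 1 the assay gives only a limit, < 10 nM, and not a number. Two numbers remain. Compound 3 gives 16100 nM, and compound 2 gives 18300 nM; the gap between compound 2 and compound 3 lies within the scatter of this assay, so the two stand together and neither can be set above the other. Going by the values given here, compound 3 thus sits at one of the two numbers known, with compound 1 known only by its limit (the limit of < 10 nM in this assay, at which 1 of the 3 values shown sits).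

Compound 4, `Nc1ccccc1C(=O)N/N=C/C1=C(Cl)c2ccccc2CCC1`, is made from compound 3 by one change: amino in place of hydrogen on an aromatic carbon. Among the compounds with values here, no step between two measured compounds touches this position, so there is nothing to lean on for its size. The shared core and the hydrazone linker are untouched, and only the outer phenyl carries the new group. One would therefore expect the step from compound 3 to compound 4 in this assay to be small, with no direction favoured beyond the scatter, and the estimate is a 1.5-fold lower number from compound 3 to compound 4 (0.17 log units; within the scatter). For compound 4 the estimated value is 11000 nM, within a range from 3500 nM to 35000 nM.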

Compound 4, concentration for 50% growth inhibition: 51000 nM
Beside the measured number, compound 4's estimate is 4.6-fold (0.67 log units) below it; the whole stated range lies below it.
By their numbers in this assay, from the lowest: compounds 3 and 2 (each within the scatter of the next); then compound 4. At a limit, below all of these: compound 1.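

In this assay, the outer phenyl of compound 3 proves not to be indifferent to substitution: the change from phenyl to 2-aminophenyl gives a 3.2-fold higher number from compound 3 to compound 4 (0.50 log units; beyond the scatter). Amino in place of hydrogen on this aromatic carbon, ortho to a large group, therefore weakens inhibition of growth here instead of leaving it unchanged, and this is the first reading of any single change in the set, as the earlier compounds offered no step between them. Nothing measured among the compounds shown bears on why the amino group has this effect.

As far as these compounds go, it remains open whether this step belongs to amino itself or would come with any group on the same carbon, and a hydroxyl, a methyl or a fluorine there would separate those two readings. Also open, from the compounds shown here alone, is whether a carboxylic acid or an acetamide on the outer phenyl would move the number in the same direction, and whether an amine on another carbon of that ring would do so; one step on one compound sets no trend.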